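Ortho-Aryl Imidazolines: Three Measured Analogues and One Estimate

This account rests on a few compounds, and the source may have more. Where it says the series, first, only, none or still open, it means among the compounds named here.

Three analogues sharing one core were tested in a functional assay for activation of Alpha-1A adrenergic receptor (Homo sapiens), read by calcium flux; a lower number here means that less compound is needed, a higher number that more compound is needed for the effect. Compound 1 `CCN(CC)C(=O)c1ccccc1OCC1=NCCN1` gives only a limit, < 5020 nM, not a number (the limit of < 5020 nM in this assay, at which 1 of the 3 values shown sits). Compound 2 `c1cncc(-c2ccccc2OCC2=NCCN2)c1` gives 2 nM, the lowest of the two numbers, while compound 3 `Cc1cccc(-c2ccccc2OCC2=NCCN2)n1` gives 126 nM, a gap beyond the usual scatter. The untested compound 4 `c1coc(-c2ccccc2OCC2=NCCN2)c1` differs from compound 2 by one change: furan-2-yl in place of pyridin-3-yl on an aromatic carbon. For the measured compounds named here, with no directly comparable pair among the measured compounds, the step from compound 2 to compound 4 in this assay is expected to be a modest rise, near the edge of the scatter, a 5.0-fold higher number from compound 2 to compound 4 (0.70 log units; beyond the scatter). Compound 4 is therefore estimated at 10 nM, within 2 nM to 60 nM.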

Compound 4, half-maximal effective concentration: 1.26 nM
For compound 4 the middle estimate is 7.9-fold (0.90 log units) above the measured one; the measured number lies below the stated range.
By their numbers in this assay, from the lowest: compounds 4 and 2 (each within the scatter of the next); then compound 3.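

In this assay the step is a 1.6-fold lower number from compound 2 to compound 4 (0.20 log units; within the scatter) when furan-2-yl takes the place of pyridin-3-yl on an aromatic carbon, ortho to a group of 7 heavy atoms. This shows that, for this pair, a five-membered aromatic ring with oxygen as its hetero atom serves at this position as well as a six-membered one with nitrogen. Nothing measured here accounts for this match. On these data alone, whether a thiophene ring, an open-chain amine or a carboxylic acid on this carbon would keep the number this low remains open.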